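Compound 2 to compound 4: carboxy on the chain

A few compounds are considered here, and "the series" means these few. Any claim that something is new, unique, unknown or untested is made for them only; others in the source may bear on it.

Among the compounds with values here, in a functional assay on OVCAR-8 cells (Homo sapiens) for antiproliferative activity (a lower number here means a stronger inhibitor, a higher number a weaker inhibitor), compound 2 (`Cn1ncc(Cl)c1-c1cc(C(=O)N[C@@H]2CN[C@H](CCn3cncn3)C[C@H]2c2ccc(Cl)c(Cl)c2)oc1Cl`) gives 1560 nM (the highest of the three numbers so far), while compound 1 (`Cn1ncc(Cl)c1-c1cc(C(=O)N[C@@H]2CN[C@H](CCCO)C[C@H]2c2ccc(Cl)c(Cl)c2)oc1Cl`) gives 600 nM and compound 3 (`Cn1ncc(Cl)c1-c1cc(C(=O)N[C@@H]2CN[C@H](CCO)C[C@H]2c2ccc(F)c(F)c2)oc1Cl`) gives 460 nM (in the same assay).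

Compound 4 (`Cn1ncc(Cl)c1-c1cc(C(=O)N[C@@H]2CN[C@H](CC(=O)O)C[C@H]2c2ccc(Cl)c(Cl)c2)oc1Cl`) differs from compound 2 in one place, on a saturated chain carbon bound to a saturated ring carbon: carboxy in place of (1H-1,2,4-triazol-1-yl)methyl (carboxy in place of (1H-1,2,4-triazol-1-yl)methyl on a saturated chain carbon bound to a saturated ring carbon).

Within the data shown here, one measured step bears on this change, since it alters the same side chain while the rest of the molecule stays fixed: a 2.6-fold higher number from compound 1 to compound 2 (0.41 log units; beyond the scatter) is modest but beyond the scatter. Compound 3 differs from compound 1 in more than one place, so it offers no clean comparison. Among the measured compounds shown here, no carboxy compound has been measured yet, so that single step sets the scale of the expected change but does not fix its direction.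

A modest move of similar size toward a higher number in this assay is the working expectation, held with low confidence. The expected step is a 2.2-fold higher number from compound 2 to compound 4 (0.35 log units; beyond the scatter) on this estimate. For compound 4 the estimated value is 3500 nM (expected range 1000 nM to 12000 nM).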

Compound 4, half-maximal inhibitory concentration: 5120 nM
Compound 4: the middle estimate sits 1.5-fold (0.17 log units) below what was measured, and the stated range covers the measured number.
By their numbers in this assay, from the lowest: compounds 3 and 1 (each within the scatter of the next); then compound 2; then compound 4.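

In this assay, the side chain on the saturated ring carbon tolerates carboxy less well than either earlier end group, with a 3.3-fold higher number from compound 2 to compound 4 (0.52 log units; beyond the scatter) and, measured against the hydroxyl-ended chain, an 8.5-fold higher number from compound 1 to compound 4 (0.93 log units; beyond the scatter). The earlier step showed only that this position responds to a change of end group; with three side chains now compared on one core, the numbers rise in the order compound 1, compound 2, compound 4, each gap beyond the scatter, and the group with the fewest heavy atoms, carboxy, carries the highest number, so the loss does not track the size of the group or need a ring. Nothing measured here accounts for this order, and no data on the cause are available for these compounds.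

Going by these compounds, whether the loss belongs to the carboxylic acid itself or to the shorter chain it sits on stays open, since a carboxylic acid on a longer chain, a methyl ester or a primary amide at this place would separate the two. An amine at the end of the same chain would show whether the hydroxyl end of compound 1 can be matched by another group.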